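The source may report more compounds than this note shows. Statements on the series, on what has been measured and on what is new or still open speak of the compounds shown alone.

Compound 1, `Cc1ccc2oc(CSc3nc4nc(C)cc(C)n4n3)cc(=O)c2c1`, gives > 25000 nM in a functional assay on MDA-MB-435S cells (Homo sapiens) for cytotoxicity, read by MTT assay, with a stated time of 72 h (on this read-out lower numbers stand for stronger inhibition and higher numbers for weaker inhibition), which is a limit of the assay and not a number. Compound 2, `Cc1cc(C)n2nc(SCc3cc(=O)c4cc(Cl)ccc4o3)nc2n1`, also stops at a limit in this assay, > 25000 nM. Compound 3, `Cc1ccc2oc(CSc3nnc(C)s3)cc(=O)c2c1`, likewise reaches only a limit in this assay, > 25000 nM.

Compound 2 differs from compound 1 by chloro in place of methyl on an aromatic carbon. Because both values are limits, the step that the two limits leave unreadable from compound 1 to compound 2 cannot be read. The difference between the core of compound 1 and the core of compound 3 is not broken down here. Compound 4, `Cc1nnc(SCc2cc(=O)c3cc(Cl)ccc3o2)s1`, differs from compound 3 by chloro in place of methyl on an aromatic carbon; the place is described in the same words as for the change from compound 1 to compound 2, so this is the same change. Every measured value sits at the limit of > 25000 nM in this assay, at which 3 of the 3 values shown sit. Since the same change left compound 2 at a limit, the step from compound 3 to compound 4 is expected to be a step that the limit leaves unreadable from compound 3 to compound 4, an expectation without a readable number behind it. Compound 4 is therefore estimated at 35000 nM in this assay, most likely again only a limit, with a range from 12000 nM to 100000 nM.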

Compound 4, half-maximal inhibitory concentration: > 25000 nM
Compound 4: a limit, no number; the forecaster's own chance of this, stated with the estimate: 85%; the middle value does not contradict the limit.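

Compound 3 and compound 4 both stop at a limit, not a number, so no step between them can be read: the limit of > 25000 nM in this assay, at which 4 of the 4 values shown sit.

Going by these compounds, whether chloro in place of methyl changes anything in this assay at all stays open.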